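This account rests on a few compounds, and the source may have more. Where it says the series, first, only, none or still open, it means among the compounds named here.

Measured compounds:
- compound 1, `CCCN(C)c1nc(C)nc2c(-c3c(C)cc(OC)cc3OC)c(C)nn12`, 6.48 nM
- compound 2, `CCC(CC)Nc1nc(C)nc2c(-c3cc(F)c(OC)cc3C)c(C)nn12`, 1.9 nM

In an assay on cell membranes for displacement of a labelled ligand from corticotropin-releasing factor receptor 1 (Rattus norvegicus) (on this read-out lower numbers stand for stronger inhibition and higher numbers for weaker inhibition), compound 1 gives 6.48 nM, the higher of the two numbers recorded so far. Compound 2 gives 1.9 nM, a lower number, and the gap between the two lies beyond the usual scatter; compound 2 differs from compound 1 at both the amino substituent and the aryl group, so no single-point comparison is available in this assay.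

Compound 3, `CCCN(CCC)c1nc(C)nc2c(-c3c(C)cc(OC)cc3OC)c(C)nn12`, has not been measured. It differs from compound 1 by one change: ethyl in place of hydrogen on a saturated chain carbon bound to a nitrogen on an aromatic ring. Only compound 1 shares the aryl group of compound 3, and nothing in the present data isolates the effect of lengthening the chain on the amino nitrogen while the rest of the molecule is held constant.

Among the measured compounds shown here, with no measured step to lean on, the expectation for compound 3 is a small move toward a lower number, a 1.9-fold lower number from compound 1 to compound 3 (0.27 log units; within the scatter), close to the edge of the scatter rather than clearly beyond it. Compound 3 is therefore estimated at 3.5 nM, with a range from 1.4 nM to 9 nM.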

Compound 3, half-maximal inhibitory concentration: 3.72 nM
The estimate for compound 3 lay 1.1-fold (0.03 log units) below the measured number, and the stated range covers the measured number.
By their numbers in this assay, from the lowest: compounds 2, 3 and 1 (each within the scatter of the next, the first and the last beyond it).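

In this assay, among the compounds shown here, compounds 1 and 3 form the first pair that differ in one place, giving a direct reading of this position with the aryl group and the rest of the shared core held constant: a 1.7-fold lower number from compound 1 to compound 3 (0.24 log units; within the scatter). Going from methyl(propyl)amino to dipropylamino, a change of methyl to propyl that adds two carbons, therefore leaves the number within the scatter, so this change is accommodated in this assay, on the evidence of this one pair. Nothing available explains this result.

From the compounds shown here alone, whether dibutylamino or bis(2-methoxyethyl)amino in place of dipropylamino would also stay within the scatter of compound 3 remains open, so the limit of this accommodation is undefined. Going by these compounds, compound 2 differs from compound 3 at both the amino substituent and the aryl group, so the separate contribution of each of those two changes remains open, as does whether the methyl to propyl result would carry over to the aryl group of compound 2.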